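Thiourea aryl variation in the shared core series

The compounds below may be only part of what the source reports. "The series", "measured", "known", "first", "only" and "open" are said of these compounds alone.

Three thioureas built on the shared core have been run in a functional assay on HL-60 cells (Homo sapiens) for antiproliferative activity, with a stated time of 24 h; a higher number here means a weaker inhibitor, a lower number a stronger inhibitor. Compound 1 `NC(=O)c1c(NC(=O)c2ccccc2Cl)sc2c1CCN(C(=S)Nc1ccccc1F)C2` gives 4970 nM; compound 2 `NC(=O)c1c(NC(=O)c2ccccc2Cl)sc2c1CCN(C(=S)Nc1ccccc1C(F)(F)F)C2` gives 10600 nM; compound 3 `Cc1ccccc1NC(=S)N1CCc2c(sc(NC(=O)c3ccccc3Cl)c2C(N)=O)C1` gives 22600 nM. Compound 3 stands highest of the three, with a 2.1-fold higher number from compound 2 to compound 3 (0.33 log units; beyond the scatter) and a 4.5-fold higher number from compound 1 to compound 3 (0.66 log units; beyond the scatter) both beyond the scatter, and the step of a 2.1-fold higher number from compound 1 to compound 2 (0.33 log units; beyond the scatter) also falls beyond the scatter.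

Compound 4 `NC(=O)c1c(NC(=O)c2ccccc2Cl)sc2c1CCN(C(=S)Nc1ccc(C(F)(F)F)cc1)C2` is not yet measured. Relative to compound 3 the change is 4-(trifluoromethyl)phenyl in place of 2-methylphenyl on an amide-type nitrogen. For the measured compounds named here, the step that bears most directly is a 2.1-fold higher number from compound 2 to compound 3 (0.33 log units; beyond the scatter), which in reverse reads as a modest move to a lower number when trifluoromethyl replaces methyl; but no measured compound carries the 4-(trifluoromethyl)phenyl group, and compound 2 carries its trifluoromethyl as a different group on that ring, so the reading is only partial. A modest move to a lower number is expected for compound 4, a 1.9-fold lower number from compound 3 to compound 4 (0.27 log units; within the scatter), with the scatter of the measured steps leaving it uncertain. Compound 4 is estimated at 12000 nM, within 4000 nM to 36000 nM.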

Compound 4, half-maximal inhibitory concentration: 7590 nM
The estimate for compound 4 lay 1.6-fold (0.20 log units) above the measured number; the range from low to high includes it.
By their numbers in this assay, from the lowest: compounds 1, 4 and 2 (each within the scatter of the next, the first and the last beyond it); then compound 3.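

Moving trifluoromethyl from the 2-(trifluoromethyl)phenyl of compound 2 to the 4-(trifluoromethyl)phenyl of compound 4 gives a 1.4-fold lower number from compound 2 to compound 4 (0.15 log units; within the scatter) in this assay, so this pair does not separate the two placements of that group. With a 1.5-fold higher number from compound 1 to compound 4 (0.18 log units; within the scatter) as well, 4-(trifluoromethyl)phenyl also cannot be told from 2-fluorophenyl, whereas a 3.0-fold lower number from compound 3 to compound 4 (0.47 log units; beyond the scatter) leaves compound 3 as the weakest of the four, its steps to all three others being beyond the scatter. Nothing available on these compounds accounts for the order.

From the compounds shown here alone, it remains open whether 4-methylphenyl would lift the weakness of 2-methylphenyl, which would show if the ring placement of methyl matters. Going by these compounds, how an amine or a carboxylic acid on this aryl ring would read in this assay is also open.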